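The compounds below may be only part of what the source reports. "The series", "measured", "known", "first", "only" and "open" are said of these compounds alone.

Working notes on the cytotoxicity series. Among the compounds with values here, compound 2 `N#Cc1ccc(Nc2nc(Oc3c(Br)cc(Br)cc3Br)c3ccccc3n2)cc1` stands at 58000 nM in an ADME assay on MT4 cells (Homo sapiens) for cytotoxicity, read by MTT assay, with a stated time of 4 days (a higher number here means that more compound is tolerated, a lower number that less compound is tolerated), the lowest of the two numbers so far; its nearest neighbour is compound 1 `Cc1cc(C#N)cc(C)c1Oc1nc(Nc2ccc(C#N)cc2)nc2ccccc12`, which in this assay gives 203000 nM. Within the data shown here, the one step already measured, a 3.5-fold lower number from compound 1 to compound 2 (0.54 log units; beyond the scatter), is the only one that touches the oxygen-linked aryl group, and it shows that swapping that group can move this assay beyond the scatter, though only modestly.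

Compound 3 `Cc1ccc(Oc2nc(Nc3ccc(C#N)cc3)nc3ccccc23)cc1` is the next member. It differs from compound 2 by 4-methylphenyl in place of 2,4,6-tribromophenyl on an oxygen on an aromatic ring. Among the measured compounds shown here, the measured step concerns the same position, so it is the one bearing on the change, but it ran from a cyano-dimethyl aryl to a tribromo aryl, not to a plain methylphenyl, and the data give no direct guide for the methylphenyl case. The change is expected to give a modest rise, that is a step of a 2.1-fold higher number from compound 2 to compound 3 (0.32 log units; beyond the scatter), so that compound 3 is estimated to come in near 120000 nM, within the range 40000 nM to 300000 nM; a step within the scatter is also plausible.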

Compound 3, half-maximal cytotoxic concentration: 87000 nM
The estimate for compound 3 lay 1.4-fold (0.14 log units) above the measured number, and the stated range covers the measured number.
By their numbers in this assay, from the lowest: compounds 2 and 3 (each within the scatter of the next); then compound 1.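

Within this assay, the step of a 1.5-fold higher number from compound 2 to compound 3 (0.18 log units; within the scatter) puts 4-methylphenyl and 2,4,6-tribromophenyl on the oxygen within the scatter of each other, so this change, which removes all the bromine and adds one methyl group, does not separate the two compounds. Within the data shown here, the step of a 2.3-fold lower number from compound 1 to compound 3 (0.37 log units; beyond the scatter) adds what the single earlier step could not show: compound 1, with 4-cyano-2,6-dimethylphenyl, stands apart from both other compounds, and none of the three goes against this, though the gaps remain modest. No measurement at hand accounts for this difference.

The compounds shown do not tell whether the nitrile or the methyl groups of 4-cyano-2,6-dimethylphenyl, alone or together, account for the separation of compound 1 from the other two. Going by these compounds, all three carry a substituted phenyl group on the oxygen, so the effect on this number of an amine or a carboxylic acid on that phenyl ring, or of a longer alkyl chain in its place, remains open.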